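The source may hold more compounds than are shown below. What is called first, only, known or untested is meant among the compounds shown, and "the series" means these compounds.

Working notes on the series.

Compound 1 `Cc1cn(Cc2ccc(Cl)cc2Cl)c2c(-c3nnc(NS(=O)(=O)c4cc(F)c(F)cc4F)o3)cc(F)cc12` gives 64% in an assay on isolated protein with prostaglandin F2-alpha receptor (Homo sapiens) as the target, read by FLIPR, tested at 10 uM; on this read-out higher numbers stand for a stronger effect at the one concentration tested and lower numbers for a weaker effect. Compound 2 `Cc1cn(Cc2ccc(Cl)cc2Cl)c2c(-c3nnc(NS(=O)(=O)c4ccc(Cl)c(Cl)c4)o3)cc(F)cc12` gives -1% in the same assay, and compound 3 `Cc1cn(Cc2ccc3ccccc3c2)c2c(-c3cc(NS(=O)(=O)c4ccc(F)c(F)c4)no3)cc(F)cc12` gives 6%. Compound 2 stands lowest of the three numbers: compound 3 lies nearest, within the scatter, and compound 1 furthest, beyond the scatter. Among the measured compounds shown here, the one measured step at the sulfonyl sulfur is a number 65 percentage points lower from compound 1 to compound 2 (beyond the scatter), a large fall.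

Compound 4 `Cc1cn(Cc2ccc(Cl)cc2Cl)c2c(-c3nnc(NS(=O)(=O)c4ccc(F)c(F)c4)o3)cc(F)cc12` is not yet measured. It differs from compound 2 by 3,4-difluorophenyl in place of 3,4-dichlorophenyl on a sulfonyl sulfur.

For the measured compounds named here, the only step that bears on this change is the one from compound 1 to compound 2, where a fluorinated ring on the sulfonyl sulfur gave the higher number and the dichlorinated ring the lower one; this points upward for compound 4. Compound 3 carries the same 3,4-difluorophenyl on a different core and gives only 6%, so the size of the rise is uncertain. For compound 4 a moderate rise is expected, a number 31 percentage points higher from compound 2 to compound 4 (beyond the scatter), giving an estimate of 30% with a range from 0% to 65% in this assay.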

Compound 4, a percentage reported as activity, at one concentration (the size of the read-out at that concentration, not a potency): 41%
Compound 4: the middle estimate sits 11 percentage points below what was measured; the range from low to high includes it.
By their numbers in this assay, from the lowest: compounds 2 and 3 (each within the scatter of the next); then compound 4; then compound 1.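

On the sulfonyl sulfur, 3,4-difluorophenyl in place of 3,4-dichlorophenyl gives, in this assay, a number 42 percentage points higher from compound 2 to compound 4 (beyond the scatter), so the earlier fall does not need the full 2,4,5-trifluorophenyl group to be reversed in large part. Hydrogen in place of fluoro on an aromatic carbon of that ring still leaves a number 23 percentage points lower from compound 1 to compound 4 (beyond the scatter), a modest step beyond the scatter, so the third fluoro adds to the read-out but does not account for all of it. Nothing in hand explains either step.

On these data alone, it remains open whether one chloro or both go with the low number, which a 3-chloro-4-fluorophenyl group would address. As far as these compounds go, the read-out with an unsubstituted phenyl or a 3,4-dimethylphenyl group on the same sulfur, and whether these steps hold on the core of compound 3, also remain open.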